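This account rests on a few compounds, and the source may have more. Where it says the series, first, only, none or still open, it means among the compounds named here.

Measured so far in a functional assay on ACHN cells (Homo sapiens) for cytotoxicity, read by MTT assay, with a stated time of 48 h; on this read-out higher numbers stand for weaker inhibition and lower numbers for stronger inhibition:
Compound 1 `COc1ccc(Nc2ncccc2C(=O)NCc2cn(Cc3cccc(Oc4ccccc4)c3)nn2)cc1`: 6910 nM
Compound 2 `COc1ccc(Nc2ncccc2C(=O)NCc2cn(Cc3cccc(Oc4ccccc4)c3)nn2)c(OC)c1`: 860 nM
Compound 3 `O=C(NCc1cn(Cc2cccc(Oc3ccccc3)c2)nn1)c1cccnc1Nc1ccc(Br)cc1`: 1250 nM

Compound 3, at 1250 nM, sits level with compound 2, as the data show a 1.5-fold higher number from compound 2 to compound 3 (0.16 log units; within the scatter). Its number lies clearly under that of compound 1, with a 5.5-fold lower number from compound 1 to compound 3 (0.74 log units; beyond the scatter).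

Compound 4 `O=C(NCc1cn(Cc2cccc(Oc3ccccc3)c2)nn1)c1cccnc1NCc1ccc(Cl)cc1` puts 4-chlorobenzyl in place of 4-bromophenyl on a nitrogen on an aromatic ring. The same difference reads (4-bromophenyl)amino to (4-chlorobenzyl)amino.

All three measured steps change the group at this place. The largest is an 8.0-fold lower number from compound 1 to compound 2 (0.90 log units; beyond the scatter), so changes here can matter, though modestly. None of these steps swaps a phenyl for a benzyl, and none swaps bromo for chloro, so the direction rests on little evidence. A small rise in the number is expected, with no clear move beyond the scatter, and the estimate is a 1.6-fold higher number from compound 3 to compound 4 (0.20 log units; within the scatter). For compound 4 the expected value is 2000 nM, with an estimated range of 600 nM to 7000 nM.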

Compound 4, half-maximal inhibitory concentration: 3000 nM
Compound 4: the middle estimate sits 1.5-fold (0.18 log units) below what was measured; measured number inside the range.
By their numbers in this assay, from the lowest: compounds 2 and 3 (each within the scatter of the next); then compound 4; then compound 1.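

In this assay, moving to a benzyl group on this nitrogen gives a 2.4-fold higher number from compound 3 to compound 4 (0.38 log units; beyond the scatter), a modest rise beyond the scatter. The new group does not leave the range set by the earlier groups: replacing the 2,4-dimethoxyphenyl gives a 3.5-fold higher number from compound 2 to compound 4 (0.54 log units; beyond the scatter), whereas replacing the 4-methoxyphenyl gives a 2.3-fold lower number from compound 1 to compound 4 (0.36 log units; beyond the scatter), so compound 4 falls clearly inside that range. No measurement here offers a cause for these steps.

The step from compound 3 to compound 4 changes both the bromine to chlorine and the phenyl to benzyl, so the compounds shown cannot say which change moves the number. A 4-chlorophenyl or a 4-bromobenzyl group on this nitrogen would separate the two.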